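The compounds below may be only part of what the source reports. "The series", "measured", "known", "first", "only" and "open" are said of these compounds alone.

Measured so far in an ADME assay for permeability, using PAMPA, at pH 7.4; on this read-out lower numbers stand for lower permeability and higher numbers for higher permeability

Compound 1 `CC(C)Cc1ccc(-c2cn(C)c3cc(C(=O)NS(C)(=O)=O)ccc23)cc1` gives "not determined" (no result reported)
Compound 2 `Cn1cc(-c2ccc(C(F)(F)F)cc2)c2ccc(C(=O)NS(=O)(=O)C3CC3)cc21` gives 135 nm/s
Compound 3 `Cn1cc(-c2ccc(C(F)(F)F)cc2)c2cc(F)c(C(=O)NS(C)(=O)=O)cc21` gives 140 nm/s

Compound 3 at 140 nm/s and compound 2 at 135 nm/s stand within the scatter of each other, while compound 1 offers no number for comparison. Compound 4 `Cn1cc(-c2ccc(C(F)(F)F)cc2)c2ccc(C(=O)NS(C)(=O)=O)cc21` differs from compound 3 by a single change (hydrogen in place of fluoro on an aromatic carbon): hydrogen in place of fluoro on an aromatic carbon. For the measured compounds named here, no measured pair shows this change alone. Compound 2 also carries hydrogen on that carbon, but has cyclopropyl where compound 3 has methyl, and compound 2 gives 135 nm/s in this comparison. No step beyond the scatter is therefore expected in this assay for this change. The expected step is a 1.2-fold lower number from compound 3 to compound 4 (0.07 log units; within the scatter) and is estimated to stay within the scatter. Compound 4 is estimated at 120 nm/s with an expected range from 60 nm/s to 240 nm/s on this read-out.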

Compound 4, apparent permeability: 171 nm/s
Compound 4: middle estimate off by 1.4-fold (0.15 log units), on the low side, within the range that was stated.
By their numbers in this assay, from the lowest: compounds 2, 3 and 4 (each within the scatter of the next).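

For the compounds shown here, compound 4 gives the first measured pair for hydrogen in place of fluoro on the aromatic carbon ortho to a (methylsulfonyl)carbamoyl group: in this assay this change gives a 1.2-fold higher number from compound 3 to compound 4 (0.09 log units; within the scatter) and, on the sulfonyl sulfur, methyl in place of cyclopropyl gives a 1.3-fold higher number from compound 2 to compound 4 (0.10 log units; within the scatter). Neither change moves this read-out beyond the scatter. Nothing at hand explains these results. Still open, from the compounds shown here alone, is whether an amine on that aromatic carbon, or a longer chain on the sulfonyl sulfur, would give a step beyond the scatter.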